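The source may hold more compounds than are shown below. What is called first, only, known or untested is meant among the compounds shown, and "the series" means these compounds.

Working notes on the series.

The series shares one core; compound 1 `Cc1ccc(-c2cc3[nH]c(=O)n(CCN4CCN(c5ccccc5Cl)CC4)c(=O)c3[nH]2)cc1` carries a chlorine on the piperazine-linked phenyl, whereas compound 2 `COc1ccccc1N1CCN(CCn2c(=O)[nH]c3[nH]c(-c4ccccc4)cc3c2=O)CC1` and compound 3 `COc1ccccc1N1CCN(CCn2c(=O)[nH]c3[nH]c(-c4ccccc4C)cc3c2=O)CC1` carry a methoxy there. In an assay on isolated protein for binding affinity to Adrenergic receptor alpha-1 (Homo sapiens) (on this read-out lower numbers stand for stronger inhibition and higher numbers for weaker inhibition), compound 1 gives 17.3 nM, compound 2 gives 1.99 nM and compound 3 gives 1.19 nM. On these numbers compound 3 stands lowest, nearest to compound 2 and well apart from compound 1. Among the measured compounds shown here, the one step that can be read, from compound 2 to compound 3, is a 1.7-fold lower number from compound 2 to compound 3 (0.22 log units; within the scatter), so the methyl on the pendant phenyl did nothing beyond the scatter.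

Compound 4 `COc1ccccc1-c1cc2c(=O)n(CCN3CCN(c4ccccc4OC)CC3)c(=O)[nH]c2[nH]1` differs from compound 3 by methoxy in place of methyl on an aromatic carbon, that is 2-methylphenyl to 2-methoxyphenyl. For the measured compounds named here, no measured pair in this assay exchanges methyl for methoxy at that position; the only related step, from compound 2 to compound 3, was within the scatter. A step of similar small size is therefore expected, a 1.3-fold higher number from compound 3 to compound 4 (0.10 log units; within the scatter), with no direction claimed. Compound 4 is estimated at 1.5 nM, within 0.5 nM to 5 nM.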

Compound 4, inhibition constant: 1.63 nM
For compound 4 the middle estimate is 1.1-fold (0.04 log units) below the measured one, within the range that was stated.
By their numbers in this assay, from the lowest: compounds 3, 4 and 2 (each within the scatter of the next); then compound 1.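

In this assay, exchanging 2-methylphenyl for 2-methoxyphenyl gives a 1.4-fold higher number from compound 3 to compound 4 (0.14 log units; within the scatter), and methoxy in place of hydrogen on the same aromatic carbon gives a 1.2-fold lower number from compound 2 to compound 4 (0.09 log units; within the scatter). Together with the earlier methyl step, this means that hydrogen, methyl and methoxy at this position on the pendant phenyl cannot be told apart on these numbers, so adding an oxygen and a hydrogen-bond acceptor there shifts nothing beyond the scatter. No data accompany these compounds that would explain this flat response.

On these data alone, it remains open whether an amine, a carboxylic acid or a longer chain at this position would move the number beyond the scatter. Compound 1 differs from the other compounds in more than one place, so its steps to them cannot be read.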